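Swapping Methylsulfanyl for Trifluoromethyl on a Shared Core

A few compounds are considered here, and "the series" means these few. Any claim that something is new, unique, unknown or untested is made for them only; others in the source may bear on it.

Of the compounds shown here, two built on one core have been tested in a functional assay on LOX IMVI cells (Homo sapiens) for cytotoxicity; on this read-out lower numbers stand for stronger inhibition of growth and higher numbers for weaker inhibition of growth. Compound 1 `COc1ccccc1C#Cc1ccccc1C#CCCCCO` gives 17900 nM in this assay, and compound 2 `CSc1ccccc1C#Cc1ccccc1C#CCCCCO` gives 5800 nM. Within the data shown here, the one measured step, a 3.1-fold lower number from compound 1 to compound 2 (0.49 log units; beyond the scatter), places compound 2 at the lower of the two numbers, the stronger growth inhibitor of the pair. Compound 3 `OCCCCC#Cc1ccccc1C#Cc1ccccc1C(F)(F)F` is not yet measured. It differs from compound 2 in one place: trifluoromethyl in place of methylsulfanyl on an aromatic carbon. Among the measured compounds shown here, no measured step involves a trifluoromethyl group, so the only comparison available bears on this change loosely, showing that exchanging the group at this aromatic carbon can move the number by a modest amount. A shift of similar size in either direction, or none beyond the scatter, is plausible. Compound 3 is therefore expected to give about 6500 nM in this assay, within a range of 2000 nM to 20000 nM. That amounts to an expected step of a 1.1-fold higher number from compound 2 to compound 3 (0.05 log units; within the scatter).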

Compound 3, concentration for 50% growth inhibition: 4900 nM
For compound 3 the middle estimate is 1.3-fold (0.12 log units) above the measured one; low and high end bracket the measured number.
By their numbers in this assay, from the lowest: compounds 3 and 2 (each within the scatter of the next); then compound 1.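

In this assay, the step of a 1.2-fold lower number from compound 2 to compound 3 (0.07 log units; within the scatter) shows that trifluoromethyl and methylsulfanyl cannot be told apart at this aromatic carbon, ortho to a large group, even though the two groups differ in heavy atoms and hydrogen-bond acceptors. The step of a 3.7-fold lower number from compound 1 to compound 3 (0.56 log units; beyond the scatter) is beyond the scatter, so a lower number on leaving methoxy is now seen with two replacements, not with methylsulfanyl alone, and compound 1 is the weakest growth inhibitor of the three. Nothing available explains these results.

The compounds shown leave open how a nitrile, an amine or a carboxylic acid at this aromatic carbon would read. They also leave open whether a shorter or longer chain on the shared core would change the picture.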